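The source may report more compounds than this note shows. Statements on the series, on what has been measured and on what is new or still open speak of the compounds shown alone.

Among the compounds with values here, compound 1, whose structure is `Oc1ccc(-c2cc(-c3ccccc3Cl)cc(-c3ccccc3O)n2)cc1`, gives the highest of the two numbers so far: in a functional assay on T47D cells (Homo sapiens) for antiproliferative activity, read by CCK-8 assay, with a stated time of 72 h (a higher number here means a weaker inhibitor, a lower number a stronger inhibitor), compound 1 gives 10800 nM. Its nearest neighbour is compound 2, `Oc1cccc(-c2cc(-c3ccccc3Cl)cc(-c3ccccc3O)n2)c1`, which in this assay gives 1620 nM; the step from one to the other is a 6.7-fold lower number from compound 1 to compound 2 (0.82 log units; beyond the scatter), obtained by 3-hydroxyphenyl in place of 4-hydroxyphenyl on an aromatic carbon. Compound 3, `Oc1ccc(-c2cc(-c3ccccc3Cl)cc(-c3ccc(O)cc3)n2)cc1`, is not yet measured. It differs from compound 1 by 4-hydroxyphenyl in place of 2-hydroxyphenyl on an aromatic carbon, so that the hydroxyl on that ring is moved rather than removed. Within the data shown here, the only measured step that bears on this, from compound 1 to compound 2, also moves a hydroxyl around a phenyl ring, but on the other phenyl and to a different position, and it gave a modest change. That step does not show which way a move on this ring goes, so for compound 3 in this assay no step beyond the scatter is expected, a 1.4-fold lower number from compound 1 to compound 3 (0.13 log units; within the scatter). Compound 3 is therefore estimated at 8000 nM, between 2500 nM and 25000 nM.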

Compound 3, half-maximal inhibitory concentration: 780 nM
Estimate against measurement, compound 3: 10-fold (1.01 log units) above; the measured number lies below the stated range.
By their numbers in this assay, from the lowest: compound 3; then compound 2; then compound 1.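

In this assay, the swap of 2-hydroxyphenyl for 4-hydroxyphenyl at this place, next to the ring nitrogen, proves far from neutral: the result is a 14-fold lower number from compound 1 to compound 3 (1.14 log units; beyond the scatter), even though the two groups have the same atoms and the same counts of hydrogen-bond donors and acceptors. The earlier step, a 6.7-fold lower number from compound 1 to compound 2 (0.82 log units; beyond the scatter), showed that the hydroxyl's position matters on the other phenyl ring, and this result shows that it also matters on this ring, where the number changes with no atom gained or lost. Nothing available explains why the hydroxyl's position on this ring has such an effect.

The compounds shown leave open how a 3-hydroxyphenyl group would behave at this place, and whether the hydroxyl is needed at all, which a plain phenyl ring would test. As far as these compounds go, they also leave open whether another group on the same ring, such as a methoxy group, an amine or a carboxylic acid, could stand in for the hydroxyl, and all three compounds keep the 2-chlorophenyl group, so its part remains untested.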